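The source may report more compounds than this note shows. Statements on the series, on what has been measured and on what is new or still open speak of the compounds shown alone.

Measured so far in a functional assay on the whole organism with Mus musculus as the target, in the maximal electroshock model, at a dose of 50 mg/kg by the oral route; on this read-out higher numbers stand for more inhibition at the one dose given (going by the name of the read-out) and lower numbers for less inhibition:

compound 1, `COc1ccccc1/C=C/c1ccccc1OCCCCN(C)C`: 0%
compound 2, `C(=C/c1ccccc1OCCCCN1CCCCC1)\c1ccccc1`: 42.9%

Compound 2 holds the highest of the two numbers; its nearest neighbour, compound 1, lies a wide gap lower, beyond the scatter. For the measured compounds named here, no single-place step connects compound 1 and compound 2, so that pair tells only what its two values show and gives no guide to how one change moves the read-out.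

The move followed here runs from compound 2 to compound 3, `O=C(O)C1CCCN(CCCCOc2ccccc2/C=C/c2ccccc2)C1`, which is not yet measured in this assay. The change is carboxy in place of hydrogen on a saturated ring carbon. Going by the values given here, no measured pair in the set shares this kind of change, so the size of its effect rests on expectation alone. The anchor is compound 2 with 42.9% in this assay. The step from compound 2 to compound 3 is expected to be downward and beyond the scatter, as a number 27.9 percentage points lower from compound 2 to compound 3 (beyond the scatter). Compound 3 is thus estimated at 15% in this assay, with a range from 0% to 45%; a wide range is warranted, as nothing measured bears directly on the new group.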

Compound 3, a percentage reported as inhibition, in the whole organism at one dose (the size of the read-out at that dose, not a potency): 12.5%
Estimate against measurement, compound 3: 2.5 percentage points above; the range from low to high includes it.
By their numbers in this assay, from the lowest: compound 1; then compound 3; then compound 2.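

This gives the series its first single-place step in this assay: going from piperidin-1-yl to 3-carboxypiperidin-1-yl gives a number 30.4 percentage points lower from compound 2 to compound 3 (beyond the scatter) and so shows that the read-out responds to a change at this saturated ring carbon, two ring bonds from the ring nitrogen. The change is small in count, with carboxy adding 3 heavy atoms, yet the step is large, and compound 3 still gives 12.5% at the one dose tested, so the carboxy-bearing ring lowers the inhibition without taking it to nothing. Nothing in hand explains why this step is so large.

A single step cannot separate an effect of carboxy itself from an effect of any substituent on this ring carbon, and a methyl ester or a primary amide at the same place would tell those two readings apart. Also open, going by these compounds, is whether a methyl group there, with neither oxygen of the carboxy, would leave the read-out of compound 2 in place.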